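Shrinking the amine on the shared core of compound 2

A few compounds are considered here, and "the series" means these few. Any claim that something is new, unique, unknown or untested is made for them only; others in the source may bear on it.

Compound 2 `CC(C)C(=O)NC1CCN(c2ccc3cc(NC(=O)CCc4ccc(C(F)(F)F)cc4)ccc3n2)C1` gives 90 nM in a functional assay on HEK293 cells for activation of melanin-concentrating hormone receptor 1 (Rattus norvegicus), read by inositol phosphate accumulation (on this read-out higher numbers stand for an effect only at larger amounts of compound and lower numbers for an effect already at smaller amounts), the lowest of the two numbers measured, with compound 1 `O=C(CCc1ccc(C(F)(F)F)cc1)Nc1ccc2nc(N3CCC(c4ccccc4)C3)ccc2c1` giving 1770 nM. Compound 3 `CN(C)c1ccc2cc(NC(=O)CCc3ccc(C(F)(F)F)cc3)ccc2n1` has not been measured; it carries dimethylamino in place of 3-((isopropylcarbonyl)amino)pyrrolidin-1-yl on an aromatic carbon. Going by the values given here, the only measured step, a 20-fold lower number from compound 1 to compound 2 (1.29 log units; beyond the scatter), changed the same saturated ring and was large. Since compound 3 loses that whole ring, its amide hydrogen included, a large step in the opposite direction is expected, though without a measured example no size is certain. Compound 3 is therefore estimated at 1500 nM, expected within 300 nM to 8000 nM, a change of a 17-fold higher number from compound 2 to compound 3 (1.22 log units; beyond the scatter).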

Compound 3, half-maximal effective concentration: 110 nM
Compound 3: the middle estimate sits 14-fold (1.13 log units) above what was measured, and the stated range ends above it.
By their numbers in this assay, from the lowest: compounds 2 and 3 (each within the scatter of the next); then compound 1.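

At this aromatic carbon next to the ring nitrogen, the small dimethylamino group matches the far larger 3-((isopropylcarbonyl)amino)pyrrolidin-1-yl, with a 1.2-fold higher number from compound 2 to compound 3 (0.09 log units; within the scatter), so neither the ring nor its amide hydrogen is required for this level of activity. The phenyl-bearing ring alone stands apart, with a 16-fold lower number from compound 1 to compound 3 (1.21 log units; beyond the scatter), and no evidence here explains either result. Still open, from the compounds shown here alone, is whether a bare amino group or an unsubstituted pyrrolidin-1-yl at this carbon would give a similar number.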